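From 4-fluorophenyl to 3-methylphenyl: expecting a small step

This account rests on a few compounds, and the source may have more. Where it says the series, first, only, none or still open, it means among the compounds named here.

Compound 1 `Fc1ccc(/C=C/c2nnc(-c3ccc4c(c3)OCCO4)o2)cc1`: 4960 nM
Compound 2 `Fc1cccc(/C=C/c2nnc(-c3ccc4c(c3)OCCO4)o2)c1`: 3530 nM
Compound 3 `Cc1ccccc1/C=C/c1nnc(-c2ccc3c(c2)OCCO3)o1`: 40500 nM

In a functional assay on HUVEC cells (Homo sapiens) for antiproliferative activity, read by MTT assay, with a stated time of 48 h (a higher number here means a weaker inhibitor, a lower number a stronger inhibitor), the numbers form two groups: compound 1 sits together with compound 2, and compound 3 stands alone as the weakest. The gap within the pair is small, a 1.4-fold lower number from compound 1 to compound 2 (0.15 log units; within the scatter). The gaps to compound 3 are not: an 8.2-fold higher number from compound 1 to compound 3 (0.91 log units; beyond the scatter), and an 11-fold higher number from compound 2 to compound 3 (1.06 log units; beyond the scatter).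

Compound 4 `Cc1cccc(/C=C/c2nnc(-c3ccc4c(c3)OCCO4)o2)c1` keeps the shared core and changes one group: 3-methylphenyl in place of 4-fluorophenyl on a double-bonded chain carbon bound to a double-bonded chain carbon. The pair of fluorine compounds shows that 3-fluorophenyl and 4-fluorophenyl cannot be told apart here. Going by the values given here, the only methyl compound measured is 2-methylphenyl, so no measurement shows whether the jump to compound 3 follows from the methyl group or from its place on the ring.

A small step towards a higher number in this assay is therefore expected, possibly within the scatter, and the high value of compound 3 at 40500 nM stretches the upper end of the range. The expected change is a 1.4-fold higher number from compound 1 to compound 4 (0.15 log units; within the scatter). For compound 4 the estimated value is 7000 nM, with an expected range of 2500 nM to 30000 nM.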

Compound 4, half-maximal inhibitory concentration: 40600 nM
For compound 4 the middle estimate is 5.8-fold (0.76 log units) below the measured one; the whole stated range lies below it.
By their numbers in this assay, from the lowest: compounds 2 and 1 (each within the scatter of the next); then compounds 3 and 4 (each within the scatter of the next).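

In this assay the change to 3-methylphenyl costs clearly more than the opening pair suggested (an 8.2-fold higher number from compound 1 to compound 4 (0.91 log units; beyond the scatter)), and methyl in place of fluoro on an aromatic carbon does the same (a 12-fold higher number from compound 2 to compound 4 (1.06 log units; beyond the scatter)). Moving the methyl from 2-methylphenyl to 3-methylphenyl changes nothing that can be told apart (a 1.0-fold higher number from compound 3 to compound 4 (0.00 log units; within the scatter)), so among these compounds the high number goes with the methyl group wherever it was placed, not with one place on the ring. No measurement shown explains why methyl and fluoro differ here.

On these data alone, whether 4-methylphenyl would join compound 3 and compound 4 stays open. So does whether a ring carrying chloro, methoxy or an amine would fall with the fluorine pair or with the methyl pair.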